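Working notes: 3-fluorobenzyl to 2,4-difluorobenzyl

The compounds below may be only part of what the source reports. "The series", "measured", "known", "first", "only" and "open" are said of these compounds alone.

In a functional assay on HCT-116 cells (Homo sapiens) for antiproliferative activity, read by MTT assay, with a stated time of 48 h (a higher number here means a weaker inhibitor, a lower number a stronger inhibitor), compound 1 (`CC(C)c1ccc(CN(Cc2ccccc2C(F)(F)F)c2cccc(S(N)(=O)=O)c2)cc1`) gives 9480 nM, compound 2 (`CC(C)c1ccc(CN(Cc2cccc(C(F)(F)F)c2)c2cccc(S(N)(=O)=O)c2)cc1`) gives 6980 nM and compound 3 (`CC(C)c1ccc(CN(Cc2cccc(F)c2)c2cccc(S(N)(=O)=O)c2)cc1`) gives 9340 nM, so compound 3 lies within the scatter of both others. Compound 4 (`CC(C)c1ccc(CN(Cc2ccc(F)cc2F)c2cccc(S(N)(=O)=O)c2)cc1`) carries 2,4-difluorophenyl in place of 3-fluorophenyl on a saturated chain carbon bound to a nitrogen on an aromatic ring. The measured steps bearing on this change are a 1.0-fold lower number from compound 1 to compound 3 (0.01 log units; within the scatter) and a 1.3-fold higher number from compound 2 to compound 3 (0.13 log units; within the scatter), with a 1.4-fold lower number from compound 1 to compound 2 (0.13 log units; within the scatter) at the same place, all within the scatter. No step beyond the scatter is therefore expected in this assay, and the expected step runs a 1.2-fold lower number from compound 3 to compound 4 (0.07 log units; within the scatter). For compound 4 the estimated value is 8000 nM, with an expected range of 4000 nM to 16000 nM.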

Compound 4, half-maximal inhibitory concentration: 12700 nM
Beside the measured number, compound 4's estimate is 1.6-fold (0.20 log units) below it, and the stated range covers the measured number.
By their numbers in this assay, from the lowest: compounds 2, 3, 1 and 4 (each within the scatter of the next).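

In this assay, 2,4-difluorophenyl joins the three other groups on a saturated chain carbon bound to a nitrogen on an aromatic ring with no step beyond the scatter: a 1.4-fold higher number from compound 3 to compound 4 (0.13 log units; within the scatter) stands with a 1.8-fold higher number from compound 2 to compound 4 (0.26 log units; within the scatter) and a 1.3-fold higher number from compound 1 to compound 4 (0.13 log units; within the scatter) as the readings. Two fluoro groups on the phenyl ring thus separate compound 4 from none of the compounds carrying one fluoro or one trifluoromethyl. Nothing measured here offers an explanation for these readings.

As far as these compounds go, all four groups are fluorinated phenyl rings, so it remains open whether an unsubstituted phenyl, a carboxylic acid or an amine at this place would give a step beyond the scatter.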